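A few compounds are considered here, and "the series" means these few. Any claim that something is new, unique, unknown or untested is made for them only; others in the source may bear on it.

Compound 2 `COc1ccc(-c2cc(=O)c3c(OC)cc(OC)cc3n2S(=O)(=O)c2cc(Cl)cc(Cl)c2O)cc1` was tested in a functional assay on HepG2 cells (Homo sapiens) for antiproliferative activity, with a stated time of 72 h; on this read-out higher numbers stand for an effect only at larger amounts of compound and lower numbers for an effect already at smaller amounts. In that assay compound 2 gives only a limit of the assay, > 37900 nM. Its nearest relative, compound 1 `COc1ccc(-c2cc(=O)c3c(OC)cc(OC)cc3n2S(=O)(=O)c2cccc([N+](=O)[O-])c2)cc1`, also reaches only a limit, > 39600 nM. The step that the two limits leave unreadable from compound 1 to compound 2 stays unreadable because the two values sit at limits the limit of > 37900 nM in this assay, at which 1 of the 2 values shown sits (the limit of > 39600 nM in this assay, at which 1 of the 2 values shown sits). Compound 3 `COc1ccc(-c2cc(=O)c3c(OC)cc(OC)cc3n2S(=O)(=O)c2cccc(Br)c2)cc1` carries 3-bromophenyl in place of 3,5-dichloro-2-hydroxyphenyl on a sulfonyl sulfur. With only two limits to go on, no direction can be expected. Compound 3 is estimated to stay near the same limit, so the expected step that the limit leaves unreadable from compound 2 to compound 3 is small. Compound 3 is expected at 40000 nM, within 10000 nM to 120000 nM.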

Compound 3, half-maximal effective concentration: > 58600 nM
Compound 3: no number, only a limit (the forecaster's own chance of this, stated with the estimate: 70%); middle value at least 1.4-fold (0.16 log units) away from the limit.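

Among the compounds shown here, compound 1, compound 2 and compound 3 all give only limits in this assay; no step between them can be read. The compounds shown leave open whether any group on the sulfonyl sulfur changes the read-out.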